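Benzyl for cyclohexylmethyl on the shared core

A few compounds are considered here, and "the series" means these few. Any claim that something is new, unique, unknown or untested is made for them only; others in the source may bear on it.

The shared core is carried by compound 1 `CCCSc1nc(Cl)c2c(n1)N(Cc1ccccc1)C(C(=O)N1CCN(Cc3ccccc3)CC1)N2`, compound 2 `CCCSc1nc(Cl)c2c(n1)N(Cc1ccccc1)C(C(=O)O)N2` and compound 3 `CCCSc1nc(Cl)c2c(n1)N(CC1CCCCC1)C(C(=O)N1CCN(C)CC1)N2`. Going by the values given here, in a functional assay on TE-1 cells (Homo sapiens) for antiproliferative activity, read by MTT assay, with a stated time of 72 h (on this read-out higher numbers stand for weaker inhibition and lower numbers for stronger inhibition), compound 1 gives 48200 nM, the only value in the set that is a number. Compound 2 reaches only the limit > 64000 nM in this assay. Compound 3 likewise stands at the limit > 64000 nM in this assay, so its position is known as a limit only, in line with the limit of > 64000 nM in this assay, at which 2 of the 3 values shown sit. Compound 4 `CCCSc1nc(Cl)c2c(n1)N(Cc1ccccc1)C(C(=O)N1CCN(C)CC1)N2` differs from compound 3 by phenyl in place of cyclohexyl on a saturated chain carbon bound to a nitrogen on an aromatic ring in a ring. Among the compounds with values here, no measured pair carries this change, so its size is open. The benzyl of compound 4 is shared by compound 1, whose 48200 nM is a number rather than a limit, so a step toward stronger inhibition is expected for compound 4: an at least 1.4-fold lower number from compound 3 to compound 4 (0.15 log units; that floor lies within the scatter). Compound 4 is expected at 45000 nM, between 20000 nM and 90000 nM, with a real chance of a limit again.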

Compound 4, half-maximal inhibitory concentration: 42500 nM
Estimate against measurement, compound 4: 1.1-fold (0.02 log units) above; measured number inside the range.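

In this assay, benzyl in place of cyclohexylmethyl on the shared core gives an at least 1.5-fold lower number from compound 3 to compound 4 (0.17 log units; that floor lies within the scatter). 4-Methylpiperazin-1-yl in place of hydroxy on the carbonyl carbon gives an at least 1.5-fold lower number from compound 2 to compound 4 (0.17 log units; that floor lies within the scatter), and both steps start from a limit, so each is a floor: the limit of > 64000 nM in this assay, at which 2 of the 4 values shown sit. Hydrogen in place of phenyl on the saturated chain carbon bound to an amine nitrogen in a ring gives a 1.1-fold lower number from compound 1 to compound 4 (0.05 log units; within the scatter).

Going by these compounds, the true size of the cyclohexylmethyl to benzyl change stays open. So does the effect of a longer chain such as phenethyl on that ring nitrogen, or of a primary amide on the carbonyl carbon.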